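A few compounds are considered here, and "the series" means these few. Any claim that something is new, unique, unknown or untested is made for them only; others in the source may bear on it.

Of the compounds shown here, three of one series have so far been measured in a functional assay on a cell-free system (plasma, Homo sapiens), with a stated time of 3 min; on this read-out lower numbers stand for stronger inhibition and higher numbers for weaker inhibition. Compound 1 `O=C(NCc1cc(Cl)ccc1-n1cnnn1)[C@@H]1CCNN1C(=O)[C@H](O)c1ccccc1` gives 930 nM. Compound 2 `CC(C)(C)C[C@@H](O)C(=O)N1C[C@@H]2C[C@@H]2[C@H]1C(=O)NCc1cc(Cl)ccc1-n1cnnn1` gives 910 nM in this assay, and compound 3 `O=C(NCc1cc(Cl)ccc1-n1cnnn1)[C@@H]1[C@H]2C[C@H]2CN1C(=O)[C@H](O)Cc1ccccc1` gives 1200 nM. Compound 2 differs from compound 3 by tert-butyl in place of phenyl on a saturated chain carbon, two bonds along the chain from a carbonyl carbon and an oxygen on a saturated carbon, a change that gave a 1.3-fold lower number from compound 3 to compound 2 (0.12 log units; within the scatter). How the core of compound 1 differs from that of compound 3 is not broken down here; their values in this assay lie close together.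

Compound 4 `CC(C)(C)[C@@H](O)C(=O)N1NCC[C@H]1C(=O)NCc1cc(Cl)ccc1-n1cnnn1` has not yet been measured. It differs from compound 1 by tert-butyl in place of phenyl on a saturated chain carbon bound to a carbonyl carbon and an oxygen on a saturated carbon. For the measured compounds named here, this is the same kind of change as the one made between compound 3 and compound 2, but the place is not the same: in compound 4 the saturated chain carbon is bound to the carbonyl carbon and the oxygen on a saturated carbon, whereas in the earlier pair it stands two bonds along the chain from them. Because compound 1 gives 930 nM and the earlier change gave only a 1.3-fold lower number from compound 3 to compound 2 (0.12 log units; within the scatter), the expected step is a 1.2-fold lower number from compound 1 to compound 4 (0.07 log units; within the scatter). Compound 4 is therefore estimated to give 800 nM in this assay, most likely between 400 nM and 1600 nM.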

Compound 4, half-maximal inhibitory concentration: 1700 nM
For compound 4 the middle estimate is 2.1-fold (0.33 log units) below the measured one; measured number outside the range, above it.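

In this assay, tert-butyl in place of phenyl on a saturated chain carbon bound to a carbonyl carbon and an oxygen on a saturated carbon gives a 1.8-fold higher number from compound 1 to compound 4 (0.26 log units; within the scatter). Set beside the earlier step on the other core, the new step does not differ from it by more than repeated measurements would allow: the same change on two cores in this assay, a 1.3-fold lower number (0.12 log units; within the scatter) from compound 3 to compound 2 and a 1.8-fold higher number (0.26 log units; within the scatter) from compound 1 to compound 4, 2.4-fold (0.38 log units) apart, within the scatter of two such steps. For the compounds shown here, this shows that neither of the two pairs moves the number beyond the scatter, but it does not show that the exchange behaves identically on every core, as each core offers only one pair and the exchanged group sits at a different distance from the carbonyl carbon in each.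

The compounds shown leave open whether a different group at this place, such as an amine or a carboxylic acid, would move the number beyond the scatter on either core. They also leave open what happens to the number when a hydrogen takes the place of the hydroxy group.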